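The source may report more compounds than this note shows. Statements on the series, on what has been measured and on what is new or still open speak of the compounds shown alone.

For the measured compounds named here, in an assay for inhibition of 6-phosphofructo-2-kinase/fructose-2,6-bisphosphatase 3 (Homo sapiens), read by ADP-Glo, with a stated time of 2 h (a lower number here means a stronger inhibitor, a higher number a weaker inhibitor), compound 1 `CNS(=O)(=O)c1ccccc1Nc1cc(-c2ccc3ccn(C)c3c2)c2nccnc2c1` gives 104 nM, and compound 2 `Cn1ccc2ccc(-c3cc(Nc4ccccc4S(=O)(=O)N4CCOCC4)cc4nccnc34)cc21` gives 36 nM; the step of a 2.9-fold lower number from compound 1 to compound 2 (0.46 log units; beyond the scatter) is the only single-point comparison among the measured set. Compound 3 `CC(=O)N1CCC(NC(=O)c2ccncc2Nc2cc(-c3ccc4ccn(C)c4c3)c3nccnc3c2)CC1` gives 18 nM, the lowest number of the three, within the scatter of compound 2 but beyond it relative to compound 1. Compound 4 `CN1CC(NC(=O)c2ccncc2Nc2cc(-c3ccc4ccn(C)c4c3)c3nccnc3c2)C1` differs from compound 3 by 1-methylazetidin-3-yl in place of 1-acetylpiperidin-4-yl on an amide-type nitrogen. Going by the values given here, no measured step touches this amide substituent; the one measured step concerns the sulfonyl group of compound 1 and compound 2 and does not bear on it. Compound 4 is therefore expected to stay near compound 3, with an estimated 1.4-fold higher number from compound 3 to compound 4 (0.14 log units; within the scatter) and a value of 25 nM, in a range from 8 nM to 80 nM.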

Compound 4, half-maximal inhibitory concentration: 30 nM
For compound 4 the middle estimate is 1.2-fold (0.08 log units) below the measured one; low and high end bracket the measured number.
By their numbers in this assay, from the lowest: compounds 3, 4 and 2 (each within the scatter of the next); then compound 1.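

In this assay, for the compounds shown here, the substituent on the amide-type nitrogen is varied for the first time, and the swap gives a 1.7-fold higher number from compound 3 to compound 4 (0.22 log units; within the scatter). At this position, the six-membered ring can give way to the four-membered ring, and the acetyl group to methyl, with no change beyond the scatter. No evidence is available to explain this result.

The swap alters ring size and the nitrogen substituent together, and the compounds shown do not separate the two. As far as these compounds go, how a carboxylic acid or an open chain such as 2-methoxyethyl would fare on this nitrogen remains open.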